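The source may hold more compounds than are shown below. What is called first, only, known or untested is meant among the compounds shown, and "the series" means these compounds.

Compounds measured in an assay on forebrain for inhibition of Monoamine oxidase (Mus musculus) (on this read-out lower numbers stand for an effect already at smaller amounts and higher numbers for an effect only at larger amounts of compound), so far:
Compound 1 `C=C=C(CN)Cc1ccccc1` gives only a limit, > 26 umol/kg.
Compound 2 `C=C=C(CN)Cc1ccc(Cl)cc1` gives 18 umol/kg.

Compound 2 thus holds the only number shown; the other value is a limit. Compound 3 `C=C=C(CN)Cc1ccc(C)cc1` differs from it by methyl in place of chloro on an aromatic carbon. Among the compounds with values here, the one measured step that bears on this position, an at least 1.4-fold lower number from compound 1 to compound 2 (0.15 log units; that floor lies within the scatter), runs against the limit of > 26 umol/kg in this assay, at which 1 of the 2 values shown sits, and so gives no size beyond the scatter. A change of one small group for another there is therefore expected to move this assay little, if at all: the step of a 1.2-fold higher number from compound 2 to compound 3 (0.09 log units; within the scatter) is the estimate. Compound 3 is expected at 22 umol/kg, between 11 umol/kg and 44 umol/kg.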

Compound 3, dose for half-maximal effect: > 38 umol/kg
Compound 3: a limit, no number; the forecaster's own chance of this, stated with the estimate: 25%; middle value at least 1.7-fold (0.23 log units) from the limit.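

In this assay, the aromatic carbon carrying chloro in compound 2 proves sensitive to this exchange: methyl in place of chloro gives an at least 2.1-fold higher number from compound 2 to compound 3 (0.32 log units; beyond the scatter), so these two small groups are not interchangeable there. Compound 3 gives only a limit, > 38 umol/kg. The step from compound 1 to compound 3 cannot be read, as both values are limits.

As far as these compounds go, how methyl compares with hydrogen at this carbon therefore stays open. Also open, from the compounds shown here alone, is whether fluoro, bromo or methoxy there would track chloro or methyl.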